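The source may hold more compounds than are shown below. What is called first, only, known or untested is meant among the compounds shown, and "the series" means these compounds.

Measured so far:
compound 1 `COc1ccc(-n2cc(COc3ccc(/C=C/C(=O)c4cc5c(cc4O)OC(C)(C)CC5)cc3)nn2)c([N+](=O)[O-])c1` gives "not active" (no number reported)
compound 2 `CC1(C)CCc2c(ccc(C(=O)/C=C/c3ccc(OCc4cn(-c5ccc(Cl)cc5)nn4)cc3)c2O)O1` gives 102000 nM

Among the measured compounds shown here, in a functional assay on HepG2 cells (Homo sapiens) for antiproliferative activity, read by MTT assay (on this read-out lower numbers stand for stronger inhibition and higher numbers for weaker inhibition), compound 2 stands alone with 102000 nM as the only number, and compound 1 has no number to compare with it. Compound 3 `CC1(C)CCc2c(ccc(C(=O)/C=C/c3ccc(OCc4cn(-c5ccc(Br)cc5)nn4)cc3)c2O)O1` changes compound 2 in one place bromo in place of chloro on an aromatic carbon with bromo in place of chloro on an aromatic carbon, para to a large group. For the measured compounds named here, no measured pair shows this change, so no step beyond the scatter is expected in this assay in either direction. The expected step of a 1.0-fold lower number from compound 2 to compound 3 (0.01 log units; within the scatter) is therefore small. Compound 3 is estimated at 100000 nM with an expected range from 45000 nM to 220000 nM in this measurement.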

Compound 3, half-maximal inhibitory concentration: 136000 nM
For compound 3 the middle estimate is 1.4-fold (0.13 log units) below the measured one; low and high end bracket the measured number.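

Bromo in place of chloro on this ring, para to a large group, gives a 1.3-fold higher number from compound 2 to compound 3 (0.12 log units; within the scatter) in this assay. Among the compounds shown here, this is the first measured pair for the change, and at this place the read-out does not tell the two halogens apart. Nothing available bears on the reason for this result. The compounds shown leave open whether an amine or a carboxylic acid at this position would give a step beyond the scatter. They also leave open whether a fluoro group would read the same as chloro and bromo.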